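Cytotoxicity notes: from compound 2 to compound 4

The source may report more compounds than this note shows. Statements on the series, on what has been measured and on what is new or still open speak of the compounds shown alone.

Compound 1 `O=C1Nc2ccccc2/C1=N\c1nc(NC2CC2)c2ncn(C3C=CC(CO)C3)c2n1` gives 48000 nM
Compound 2 `O=[N+]([O-])c1ccccc1/C=N/c1nc(NC2CC2)c2ncn(C3C=CC(CO)C3)c2n1` gives 13000 nM
Compound 3 `OCC1C=CC(n2cnc3c(NC4CC4)nc(/N=C(\c4ccccc4)c4ccc(Br)cc4)nc32)C1` gives 45000 nM

All three values come from a functional assay on CCRF-CEM cells (Homo sapiens) for cytotoxicity; on this read-out higher numbers stand for lower toxicity in this test and lower numbers for higher toxicity in this test. Compound 2 has the lowest of the three numbers, and the gaps to compound 1 and to compound 3 both lie beyond the scatter. Within the data shown here, no two measured compounds differ in only one place, so no measured step bears directly on the next change.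

Compound 4 `COc1ccc(/C=N/c2nc(NC3CC3)c3ncn(C4C=CC(CO)C4)c3n2)c(O)c1` has not yet been measured. It carries 2-hydroxy-4-methoxyphenyl in place of 2-nitrophenyl on a carbon with a double bond to nitrogen, counted as 2-hydroxy-4-methoxyphenyl in place of 2-nitrophenyl on a carbon with a double bond to nitrogen.

The expectation rests on the other two measured compounds. Compound 1 stands at 48000 nM and compound 3 stands at 45000 nM, so a replacement of the group on compound 2 seems more likely to raise the number than to lower it. A modest step towards a higher number in this assay is expected, near the edge of the scatter, and it is estimated as a 2.3-fold higher number from compound 2 to compound 4 (0.36 log units; beyond the scatter).

For compound 4 the estimated value is 30000 nM, with an expected range of 10000 nM to 90000 nM.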

Compound 4, half-maximal cytotoxic concentration: 100000 nM
Estimate against measurement, compound 4: 3.3-fold (0.52 log units) below, and the stated range ends below it.
By their numbers in this assay, from the lowest: compound 2; then compounds 3 and 1 (each within the scatter of the next); then compound 4.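

In this assay, among these compounds, 2-hydroxy-4-methoxyphenyl in place of 2-nitrophenyl on a carbon with a double bond to nitrogen gives a 7.7-fold higher number from compound 2 to compound 4 (0.89 log units; beyond the scatter), the only single-place step so far. With the rest of the structure unchanged, this step shows that the group at this position alone can move the number beyond the scatter, towards lower toxicity in this test, which compounds 1, 2 and 3 could not show because they differ in more than one place. No measurement shown accounts for the size of this step.

This change removes the nitro group and brings in hydroxy and methoxy at once, so the contribution of each remains unresolved. A phenyl carrying only hydroxy, only methoxy or only an amine at this position would help separate them.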